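The source may hold more compounds than are shown below. What is called first, only, known or untested is meant among the compounds shown, and "the series" means these compounds.

Measured so far:
Compound 1 `O=C(Nc1cccc(-c2ccc(F)cc2)c1)C(Cl)Cl`: > 50000 nM
Compound 2 `O=C(Nc1cc(-c2ccc(OC3CCCCO3)cc2)cc(-c2ccc(OC3CCCCO3)cc2)c1)C(Cl)Cl`: 2420 nM

In a functional assay on NCI-H460 cells (Homo sapiens) for cytotoxicity, read by MTT assay, with a stated time of 68 h (on this read-out higher numbers stand for weaker inhibition and lower numbers for stronger inhibition), compound 1 gives > 50000 nM, which is a limit and not a number. Compound 1 thus stands at the limit of > 50000 nM in this assay, at which 1 of the 2 values shown sits. Compound 2 gives a true number, 2420 nM.

Compound 3 `COC(=O)c1ccc(-c2cccc(NC(=O)C(Cl)Cl)c2)cc1` keeps the core of compound 1 and alters a single substituent: methoxycarbonyl in place of fluoro on an aromatic carbon. This places methoxycarbonyl in place of fluoro on an aromatic carbon, para to a large group. Within the data shown here, no step between measured compounds is available to size this change, so the expectation rests on compound 1 alone, and that compound offers no exact starting number. In this assay, only a small step is expected, toward stronger inhibition if there is any movement at all, and it may not exceed the usual scatter. Compound 3 may well return only a limit too. The expected change is an at least 1.4-fold lower number from compound 1 to compound 3 (0.15 log units; that floor lies within the scatter). For compound 3 the estimated value is 35000 nM, with an expected range from 10000 nM to 80000 nM.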

Compound 3, half-maximal inhibitory concentration: > 50000 nM
Compound 3 ended at the assay's limit; the forecaster's own chance of this, stated with the estimate: 45%; middle value at least 1.4-fold (0.15 log units) from the limit.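

In this assay compound 3 gives > 50000 nM, which is a limit and not a number. Among these compounds, compound 1 also stands at a limit, and no step between compound 1 and compound 3 can be read. The compounds shown leave open whether methoxycarbonyl in place of fluoro on an aromatic carbon changes inhibition at all, with both compounds at the same mark: the limit of > 50000 nM in this assay, at which 2 of the 3 values shown sit.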